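This account rests on a few compounds, and the source may have more. Where it says the series, first, only, none or still open, it means among the compounds named here.

Compound 1 `Cc1cc(NC(=O)CC(=O)O)c2c(c1Oc1ccc(O)c(CC(C)C)c1)CCC2` and compound 2 `Cc1cc(NC(=O)CC(=O)O)c2c(c1Oc1ccc(O)c(CCCc3ccccc3)c1)CCC2` share one core and differ only in the group on the saturated chain carbon bound to an aromatic carbon. In an in vitro assay on cells for displacement of a labelled ligand from thyroid hormone receptor beta (Homo sapiens), with a stated time of 48 h (a higher number here means a weaker inhibitor, a lower number a stronger inhibitor), compound 1 gives 39.9 nM, and compound 2 gives 223 nM, the higher of the two numbers; the step of a 5.6-fold higher number from compound 1 to compound 2 (0.75 log units; beyond the scatter) lies beyond the scatter. Compound 3 `Cc1cc(NC(=O)CC(=O)O)c2c(c1Oc1ccc(O)c(CCc3ccc(F)cc3F)c1)CCC2` is reached from compound 2 by the change (2,4-difluorophenyl in place of benzyl on a saturated chain carbon, two bonds along the chain from an aromatic carbon). Among the measured compounds shown here, only the step from compound 1 to compound 2 bears on this, and it shows that a longer chain ending in a ring raised the number; compound 3 carries a shorter chain than compound 2 while keeping an aromatic ring, so a modest lowering is expected in this assay, though no measured pair tests the fluorines. The step of a 1.9-fold lower number from compound 2 to compound 3 (0.27 log units; within the scatter) is therefore the estimate, and compound 3 is expected to give 120 nM, with a range from 40 nM to 360 nM.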

Compound 3, inhibition constant: 12 nM
The estimate for compound 3 lay 10-fold (1.00 log units) above the measured number, outside the stated range (below it).
By their numbers in this assay, from the lowest: compound 3; then compound 1; then compound 2.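

In this assay, the change from benzyl to 2,4-difluorophenyl on a saturated chain carbon, two bonds along the chain from an aromatic carbon, gives a 19-fold lower number from compound 2 to compound 3 (1.27 log units; beyond the scatter) and so reverses the direction of the earlier step, a 5.6-fold higher number from compound 1 to compound 2 (0.75 log units; beyond the scatter), in which a group ending in a ring raised the number. Placing 2,4-difluorobenzyl where isopropyl stood gives a 3.3-fold lower number from compound 1 to compound 3 (0.52 log units; beyond the scatter) as well, so groups ending in an aromatic ring supply both the highest and the lowest number of the three. No measured information accompanies these numbers that could explain the size of this change.

The change alters both the chain length and the fluorine content, and the compounds shown do not separate the two. A plain 2-phenylethyl group, or one bearing a single fluorine or chlorine, could tell how much of the step belongs to each.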